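Swapping a Selenocyanate Chain for an Amine

The source may report more compounds than this note shows. Statements on the series, on what has been measured and on what is new or still open speak of the compounds shown alone.

Compound 1, `COc1ccc(N(C)c2nc(C)nc3ccccc23)cc1OCCC[Se]C#N`: 1040 nM
Compound 2, `Cc1nc(N(C)c2ccc([Se]C#N)c(Cl)c2)c2ccccc2n1`: 12 nM

Of the compounds shown here, two have so far been measured in a functional assay on HepG2 cells (Homo sapiens) for inhibition, read by MTT assay, with a stated time of 48 h; a lower number here means a stronger inhibitor, a higher number a weaker inhibitor. Compound 1, `COc1ccc(N(C)c2nc(C)nc3ccccc23)cc1OCCC[Se]C#N`, gives 1040 nM, the higher of the two numbers, so it is the weaker inhibitor of the pair. Compound 2, `Cc1nc(N(C)c2ccc([Se]C#N)c(Cl)c2)c2ccccc2n1`, gives 12 nM, and the gap between the two values lies well beyond the usual scatter. Going by the values given here, the two structures differ in several places at once, so no single step between them can be read off; the two values show only that compound 2 is the stronger inhibitor.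

Compound 3, `COc1ccc(N(C)c2nc(C)nc3ccccc23)cc1OCCN`, is not yet measured. It differs from compound 1 in one place: one nitrogen atom in place of a group of 4 heavy atoms (2 carbon, 1 nitrogen, 1 selenium; no ring), on a saturated chain carbon, two bonds along the chain from an oxygen on an aromatic ring. Because compound 1 already gives 1040 nM, the higher of the two numbers, and the change removes the part of the chain that holds the selenium, the number for compound 3 is expected to rise further, by a step of a 4.8-fold higher number from compound 1 to compound 3 (0.68 log units; beyond the scatter), beyond the scatter. For compound 3 the value expected in this assay is 5000 nM, within a range of 1500 nM to 20000 nM.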

Compound 3, half-maximal inhibitory concentration: 343 nM
Compound 3: middle estimate off by 15-fold (1.16 log units), on the high side; measured number outside the range, below it.
By their numbers in this assay, from the lowest: compound 2; then compound 3; then compound 1.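

Going by these compounds alone, this is the only pair here that differs in one place, so it gives the first direct reading of the group on the saturated chain carbon. In this assay, exchanging the selenium-bearing group for an amino group gives a 3.0-fold lower number from compound 1 to compound 3 (0.48 log units; beyond the scatter), a modest change but one beyond the scatter. For this pair, then, the selenium-bearing group is not required for a measurable effect on these cells, and the inhibition is stronger without it, although no measurement shown here accounts for that direction.

The compounds shown leave open whether a hydroxyl group or a carboxylic acid at this place, or a longer chain ending in an amine, would give a lower or higher number than the amino group of compound 3. Compound 2 gives 12 nM but differs from both of the others in several places, so its number cannot be tied to any single change, and whether selenium contributes to that low value remains unresolved.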